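Adding a Second Chloro Group to Compound 3

A few compounds are considered here, and "the series" means these few. Any claim that something is new, unique, unknown or untested is made for them only; others in the source may bear on it.

Of the compounds shown here, three have been measured in an assay on CHO cells for displacement of a labelled ligand from transient receptor potential cation channel subfamily V member 1 (Rattus norvegicus); on this read-out higher numbers stand for weaker inhibition and lower numbers for stronger inhibition. Compound 1 `CC(C)(C)c1ccc(CNC(=O)C(C)(C)c2ccc(NS(C)(=O)=O)c(F)c2)cc1` gives 1070 nM, compound 2 `CC(C)(C)c1ccc(CNC(=O)C2(c3ccc(NS(C)(=O)=O)cc3)CC2)cc1` gives 610 nM, and compound 3 `CC(C(=O)NCc1ccc(Cl)cc1)c1ccc(NS(C)(=O)=O)c(F)c1` gives 1060 nM. Compound 3 thus sits among numbers that all lie within the usual scatter of one another: its nearest neighbour is compound 1, and even the gap to compound 2 stays inside that scatter, so none of the three can be called stronger or weaker than the others on this evidence.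

The new compound 4 `CC(C(=O)NCc1ccc(Cl)c(Cl)c1)c1ccc(NS(C)(=O)=O)c(F)c1` differs from compound 3 in one place: chloro in place of hydrogen on an aromatic carbon. For the measured compounds named here, no measured pair in this set shows what such a change does, so the expectation rests on the change alone. A single added chloro group of this kind is expected to move the number only a little, and the step from compound 3 to compound 4 is estimated at a 1.5-fold lower number from compound 3 to compound 4 (0.18 log units; within the scatter), in the direction of slightly stronger binding at most. Compound 4 is therefore expected to give about 700 nM in this assay, within a range from 250 nM to 2500 nM.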

Compound 4, inhibition constant: 200 nM
Beside the measured number, compound 4's estimate is 3.5-fold (0.54 log units) above it; measured number below the stated range.
By their numbers in this assay, from the lowest: compound 4; then compounds 2, 3 and 1 (each within the scatter of the next).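

For the compounds shown here, changing 4-chlorophenyl to 3,4-dichlorophenyl gives a 5.3-fold lower number from compound 3 to compound 4 (0.72 log units; beyond the scatter) in this assay and is the first change in this set that can be read in one place, since the earlier compounds offered no such pair. It shows that one added chloro group, ortho to the existing chloro group and meta to a large group, is enough to move the number beyond the usual scatter. Nothing on hand says what lies behind this step.

The compounds shown leave open whether this step belongs to chloro alone or would also appear with another group at the same place, such as fluoro, methyl or methoxy. They also leave open whether the same change would have a similar effect in compound 1 or compound 2, which carry a tert-butyl group where compound 3 has its chloro group.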